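Ethynyl in place of 1-benzofuran-2-yl: a step against a limit

The source may report more compounds than this note shows. Statements on the series, on what has been measured and on what is new or still open speak of the compounds shown alone.

Compounds measured so far in an ADME assay on MRC5 cells (Homo sapiens), read by MTT assay, with a stated time of 72 h; on this read-out lower numbers stand for stronger inhibition and higher numbers for weaker inhibition:
Compound 1 `C#Cc1cn([C@@H]2O[C@H](CO)[C@@H](O)[C@H]2O)c2ncnc(SC)c12`: > 100000 nM
Compound 2 `CN(C)c1ncnc2c1c(-c1ccsc1)cn2[C@@H]1O[C@H](CO)[C@@H](O)[C@H]1O`: > 100000 nM
Compound 3 `CN(C)c1ncnc2c1c(-c1cc3ccccc3o1)cn2[C@@H]1O[C@H](CO)[C@@H](O)[C@H]1O`: > 100000 nM

Each of these entries is a limit of the assay and not a number. Compound 3 is reported as > 100000 nM, which is such a limit, so no exact position can be given for it. Compound 4 `C#Cc1cn([C@@H]2O[C@H](CO)[C@@H](O)[C@H]2O)c2ncnc(N(C)C)c12` has ethynyl in place of 1-benzofuran-2-yl on an aromatic carbon. Among the compounds with values here, the one measured step that bears on this change is a step that the two limits leave unreadable from compound 2 to compound 3, and it gives no size to carry over. Beyond that, the series offers only (the limit of > 100000 nM in this assay, at which 3 of the 3 values shown sit). Compound 1 also carries ethynyl and is reported as > 100000 nM, again a limit. On these grounds, no clear direction is expected in this assay, and compound 4 may well reach the same limit. The expected change is a number no higher from compound 3 to compound 4 (the limit leaves the size open), with nothing anticipated beyond the scatter. The estimate for compound 4 is 100000 nM. The expected range for compound 4 runs from 30000 nM to 200000 nM.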

Compound 4, half-maximal inhibitory concentration: 36100 nM
Estimate against measurement, compound 4: 2.8-fold (0.44 log units) above; low and high end bracket the measured number.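

In this assay compound 4 is the only compound shown that gives a number and not a limit, and at this aromatic carbon ethynyl in place of 1-benzofuran-2-yl gives an at least 2.7-fold lower number from compound 3 to compound 4 (0.44 log units; beyond the scatter), while ethynyl in place of thiophen-3-yl gives an at least 2.7-fold lower number from compound 2 to compound 4 (0.44 log units; beyond the scatter). Ethynyl alone does not account for this, as dimethylamino in place of methylsulfanyl, with ethynyl kept, gives an at least 2.7-fold lower number from compound 1 to compound 4 (0.44 log units; beyond the scatter), so the group on the other aromatic carbon matters as well. The step between the two aromatic ring groups cannot be read, and the three steps above give only minimum sizes: the limit of > 100000 nM in this assay, at which 3 of the 4 values shown sit.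

As far as these compounds go, it remains open how a nitrile or a propynyl chain would read at this carbon. Also open, from the compounds shown here alone, is whether methylamino or pyrrolidin-1-yl in place of dimethylamino would keep a readable number.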